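A few compounds are considered here, and "the series" means these few. Any claim that something is new, unique, unknown or untested is made for them only; others in the source may bear on it.

Three compounds share one core and differ only in the ring that hangs from a saturated chain carbon bound to a nitrogen on an aromatic ring. Compound 1 `Cc1cc(Nc2nc(NCc3ccc(F)cc3)nc3ccccc23)n[nH]1` gives 20 nM in an assay for inhibition of high affinity nerve growth factor receptor (Homo sapiens), read by HTRF, with a stated time of 30 min, in the presence of a further agent that is not named here; on this read-out higher numbers stand for weaker inhibition and lower numbers for stronger inhibition. Compound 2 `Cc1cc(Nc2nc(NCc3ccc(Cl)cc3)nc3ccccc23)n[nH]1` gives 380 nM, and compound 3 `Cc1cc(Nc2nc(NCc3ccc(F)cc3F)nc3ccccc23)n[nH]1` gives 200 nM. Compound 3 stands second highest of the three numbers: its nearest neighbour is compound 2, with a 1.9-fold lower number from compound 2 to compound 3 (0.28 log units; within the scatter), and its furthest is compound 1, with a 10-fold higher number from compound 1 to compound 3 (1.00 log units; beyond the scatter). For completeness, a 19-fold higher number from compound 1 to compound 2 (1.28 log units; beyond the scatter).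

Compound 4 `Cc1cc(Nc2nc(NCc3ccc(F)cc3F)nc3ccc(F)cc23)n[nH]1` keeps everything of compound 3 and adds one change, (fluoro in place of hydrogen on an aromatic carbon), placed on a six-membered aromatic ring of carbon only that is part of the fused system of two rings, meta to one fused ring and para to the other. For the measured compounds named here, no measured step touches that fused ring. Going by the values given here, the only step of the same kind, fluoro in place of hydrogen on an aromatic carbon, is a 10-fold higher number from compound 1 to compound 3 (1.00 log units; beyond the scatter), but it sits on the ring carried by the saturated chain carbon, not on the fused system, so it is a weak guide. The expected step is therefore small and uncertain, a 1.3-fold higher number from compound 3 to compound 4 (0.10 log units; within the scatter), with either direction possible. Compound 4 is estimated at 250 nM, expected to fall between 80 nM and 800 nM.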

Compound 4, half-maximal inhibitory concentration: 44 nM
Compound 4: middle estimate off by 5.7-fold (0.75 log units), on the high side, and the stated range ends above it.
By their numbers in this assay, from the lowest: compound 1; then compound 4; then compounds 3 and 2 (each within the scatter of the next).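

Placed on the six-membered aromatic ring of carbon only that is part of the fused system, meta to one fused ring and para to the other, fluoro in place of hydrogen strengthens inhibition in this assay, with a 4.5-fold lower number from compound 3 to compound 4 (0.66 log units; beyond the scatter). For the compounds shown here, this is the first measured change to the fused system, and it shows that this part of the molecule can shift the read-out clearly, although all earlier differences lay in the ring carried by the saturated chain carbon. The same kind of swap on that other ring went the opposite way, with a 10-fold higher number from compound 1 to compound 3 (1.00 log units; beyond the scatter), so across these two steps the direction depends on where the fluoro sits, and nothing measured here gives a reason for either direction.

Still open, as far as these compounds go, is whether the same fluoro on the fused ring would also lower the number when added to compound 1, which carries a single fluoro on its other ring. Also open, from the compounds shown here alone, is how this position would respond to another group, such as chloro, methoxy, a nitrile or an amine, and how the other aromatic carbons of that ring would respond to fluoro.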